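A few compounds are considered here, and "the series" means these few. Any claim that something is new, unique, unknown or untested is made for them only; others in the source may bear on it.

Of the compounds shown here, three built on one shared core have been tested in an ADME assay on Huh-7 cells (Homo sapiens) for cytotoxicity, read by MTT assay, with a stated time of 72 h; on this read-out higher numbers stand for lower toxicity in this test and lower numbers for higher toxicity in this test. Compound 1 `Cc1cc(=O)oc2cc(OCc3cn(-c4ccc(F)c(Cl)c4)nn3)ccc12` gives > 100 ug/mL in this assay, which is a limit of the assay rather than a number. Compound 2 `Cc1cc(=O)oc2cc(OCc3cn(-c4ccccc4F)nn3)ccc12` gives > 100 ug/mL, again a limit. Compound 3 `Cc1cc(=O)oc2cc(OCc3cn(CCO)nn3)ccc12` gives > 100 ug/mL, also a limit. Because (the limit of > 100 ug/mL in this assay, at which 3 of the 3 values shown sit), the steps a step that the two limits leave unreadable from compound 1 to compound 2, a step that the two limits leave unreadable from compound 1 to compound 3 and a step that the two limits leave unreadable from compound 2 to compound 3 cannot be sized. Compound 3 therefore stands at the same limit as the other two, with no readable ordering among them.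

Compound 4 `Cc1cc(=O)oc2cc(OCc3c[nH]nn3)ccc12` differs from compound 3 by hydrogen in place of 2-hydroxyethyl on an aromatic nitrogen. The steps from compound 1 and compound 2 to compound 3 touch the same aromatic nitrogen, and both were left unreadable by the limits, so they give no direction for the coming step. Compound 4 is expected to sit at or near the same limit, with a step of a number no higher from compound 3 to compound 4 (the limit leaves the size open) of no clear size. The estimate for compound 4 in this assay is 100 ug/mL, between 50 ug/mL and 200 ug/mL.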

Compound 4, half-maximal cytotoxic concentration: > 100 ug/mL
Compound 4: no number, only a limit; the forecaster's own chance of this, stated with the estimate: 80%; the middle value lies on the limit itself.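

Among the compounds shown here, no step from compound 1, compound 2 or compound 3 to compound 4 can be read in this assay, because all four compounds share one limit rather than a number: the limit of > 100 ug/mL in this assay, at which 4 of the 4 values shown sit. Going by these compounds, it remains open how far apart these four compounds lie, or whether they differ at all.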